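This account rests on a few compounds, and the source may have more. Where it says the series, first, only, none or still open, it means among the compounds named here.

Of the compounds shown here, three have been tested in a functional assay on A2780 cells (Homo sapiens) for inhibition, read by MTT assay, with a stated time of 72 h; a lower number here means a stronger inhibitor of growth, a higher number a weaker inhibitor of growth. Compound 1 `N#C/C(=C\c1c(F)c(F)c(F)c(F)c1F)C(=O)c1c[nH]c2ccccc12` gives 11000 nM. Compound 3 `COc1ccc(CNC(=O)/C(C#N)=C/c2ccc(C)o2)cc1` gives 60000 nM, the highest of the two numbers, so of these two compound 3 is the weaker inhibitor of growth. Compound 2 `N#C/C(=C\c1ccco1)C(=O)NCc1ccc(Cl)c(Cl)c1` gives > 50000 nM, which is a limit of the assay and not a number. That is the limit of > 50000 nM in this assay, at which 1 of the 3 values shown sits.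

Compound 4 `COc1ccc(CNC(=O)/C(C#N)=C/c2ccc(Cl)cc2)cc1` has not yet been tested. It differs from compound 3 in one place: 4-chlorophenyl in place of 5-methylfuran-2-yl on a double-bonded chain carbon bound to a double-bonded chain carbon. For the measured compounds named here, no measured pair shows this kind of change, so the size of the step in this assay can only be guessed. The numbers shown for compound 1 and compound 3 both point to weak inhibition of growth, and nothing in them favours a large move in either direction. The estimated step of a 1.5-fold lower number from compound 3 to compound 4 (0.18 log units; within the scatter) is expected to lie within the usual scatter. Compound 4 is estimated at 40000 nM in this assay, with an expected range from 10000 nM to 100000 nM.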

Compound 4, concentration for 50% growth inhibition: 7000 nM
For compound 4 the middle estimate is 5.7-fold (0.76 log units) above the measured one, and the stated range ends above it.
By their numbers in this assay, from the lowest: compounds 4 and 1 (each within the scatter of the next); then compound 3.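

In this assay, for the compounds shown here, the group on a double-bonded chain carbon bound to a double-bonded chain carbon clearly matters: 4-chlorophenyl in place of 5-methylfuran-2-yl gives an 8.6-fold lower number from compound 3 to compound 4 (0.93 log units; beyond the scatter) as the first step that can be read between two compounds differing in one place. The rest of the two molecules is the same, so this difference belongs to that single swap, which replaces a five-membered aromatic ring holding oxygen with a six-membered ring of carbon bearing chlorine. No measurement shown here explains the size of this step.

Still open, going by these compounds, is whether the chlorine or the six-membered ring itself carries the step, which a plain phenyl group, or a phenyl group bearing an amine instead of chlorine, would help to separate. Also open, on these data alone, is whether the same swap would have a similar effect with a different group on the amide nitrogen, such as a longer chain.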